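The source may report more compounds than this note shows. Statements on the series, on what has been measured and on what is new or still open speak of the compounds shown alone.

Measured so far in a functional assay on CHO cells for agonist activity at Alpha-1B adrenergic receptor (Homo sapiens), read by FLIPR and calcium flux; a higher number here means that more compound is needed for the effect, a lower number that less compound is needed:
- Compound 1 `CCS(=O)(=O)Nc1cccc2c1CCC2c1ncc[nH]1`: > 10000 nM
- Compound 2 `CS(=O)(=O)Nc1cccc2c1CCCC2c1ncc[nH]1`: > 10000 nM; > 10000 nM; > 10000 nM (3 entries)

Compound 1 gives > 10000 nM in this assay, and this is a limit of the assay rather than a number. Compound 2 gives > 10000 nM; > 10000 nM; > 10000 nM (3 entries) in this assay, each of its three entries being a limit and not a number. Going by the values given here, compound 1 therefore stands at the limit of > 10000 nM in this assay, at which 1 of the 2 values shown sits, so no single number places it, and no step between two measured compounds that differ in one place can be drawn from these two.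

Compound 3 `c1cc(-c2ncco2)c2c(c1)C(c1ncc[nH]1)CC2` differs from compound 1 in one place: 1,3-oxazol-2-yl in place of (ethylsulfonyl)amino on an aromatic carbon. Because compound 1 sits at the limit of > 10000 nM in this assay, at which 1 of the 2 values shown sits, any step to compound 3 starts from a limit, not a value. Among the compounds with values here, the expected step of an at least 2.0-fold lower number from compound 1 to compound 3 (0.30 log units; that floor lies within the scatter) from compound 1 to compound 3 in this assay is toward a smaller amount of compound needed, but only modestly and with wide uncertainty, since no measured step supports a direction. Compound 3 is estimated at 5000 nM, with an expected range from 500 nM to 20000 nM, and a fair chance that the assay again returns only a limit.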

Compound 3, half-maximal effective concentration: > 10000 nM
Compound 3 ended at the assay's limit; the forecaster's own chance of this, stated with the estimate: 55%; middle value at least 2.0-fold (0.30 log units) from the limit.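

Compound 3 gives > 10000 nM in this assay and this is a limit of the assay, not a number. Going by these compounds alone, compound 1 also rests on a limit, so no step from compound 1 to compound 3 can be read: the limit of > 10000 nM in this assay, at which 2 of the 3 values shown sit. The compounds shown leave open whether 1,3-oxazol-2-yl in place of (ethylsulfonyl)amino changes the amount of compound needed at all, and in which direction.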